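This account rests on a few compounds, and the source may have more. Where it says the series, first, only, none or still open, it means among the compounds named here.

Compound 1, `Cc1nccc(N2c3ccc(C4(NC(=O)c5ccc(F)cc5)CC4)cc3[C@H]3CC[C@H]32)n1`, and compound 2, `Cc1nccc(N2CCc3nc(C4(C(=O)Nc5ccc(F)cc5)CCC4)ccc32)n1`, were both tested in an assay on blood for inhibition of Indoleamine 2,3-dioxygenase 1 (Homo sapiens) (on this read-out higher numbers stand for weaker inhibition and lower numbers for stronger inhibition), where compound 1 gives 64 nM and compound 2 gives 430 nM. Compound 2 thus stands at the higher of the two numbers, and the gap to compound 1 lies beyond the usual scatter of the method, so compound 2 is the weaker of the two measured inhibitors on this read-out.

The next compound, compound 3, `O=C(C1CC1)N1CCc2nc(C3(C(=O)Nc4ccc(F)cc4)CCC3)ccc21`, departs from compound 2 in one place: cyclopropylcarbonyl in place of 2-methylpyrimidin-4-yl on a nitrogen on an aromatic ring in a ring. Going by the values given here, no pair of measured compounds shows this particular exchange, so its effect on this assay has to be estimated without a direct precedent. The expectation for the step is a modest move toward weaker inhibition, estimated as a 2.3-fold higher number from compound 2 to compound 3 (0.37 log units; beyond the scatter). Compound 3 is accordingly expected to give about 1000 nM in this assay, with a plausible range from 300 nM to 4000 nM.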

Compound 3, half-maximal inhibitory concentration: 330 nM
Compound 3: middle estimate off by 3.0-fold (0.48 log units), on the high side; the range from low to high includes it.
By their numbers in this assay, from the lowest: compound 1; then compounds 3 and 2 (each within the scatter of the next).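

In this assay, cyclopropylcarbonyl in place of 2-methylpyrimidin-4-yl on this nitrogen gives a 1.3-fold lower number from compound 2 to compound 3 (0.11 log units; within the scatter), so the two groups cannot be told apart on this read-out. Going by these compounds alone, this is the first view of this position, and it shows that, on the core of compound 2, the six-membered aromatic ring with its 2 hetero atoms is not needed to keep inhibition at the level of compound 2, since a non-aromatic three-membered carbon ring joined through a carbonyl serves equally well. Nothing available explains why the two groups read alike.

The compounds shown leave open whether an open-chain acyl group such as acetyl, or a simple methyl on this nitrogen, would also read alike. They also leave open how the same exchange would read on the core of compound 1.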